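Methoxy in place of hydrogen: cytotoxicity notes on three compounds

The source may report more compounds than this note shows. Statements on the series, on what has been measured and on what is new or still open speak of the compounds shown alone.

Measured so far:
compound 1 `CC(C)NC(=N)c1ccc(-c2cc3cc(C(=N)NC(C)C)ccc3o2)cc1`: > 198000 nM
compound 2 `CC(C)NC(=N)c1cccc(-c2cc3ccc(C(=N)NC(C)C)cc3o2)c1`: > 200000 nM
compound 3 `COc1cc(C(=N)NC(C)C)ccc1-c1cc2cc(C(=N)NC(C)C)ccc2o1`: 98100 nM

In an ADME assay on L6 cells (Rattus norvegicus) for cytotoxicity (a lower number here means a stronger inhibitor, a higher number a weaker inhibitor), compound 1 reaches only a limit, > 198000 nM. Compound 2 likewise reaches only a limit in this assay, > 200000 nM. Compound 3 gives a number in this assay, 98100 nM.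

Compound 1 and compound 3 differ in one place, (methoxy in place of hydrogen on an aromatic carbon). The step is an at least 2.0-fold lower number from compound 1 to compound 3 (0.30 log units; that floor lies within the scatter); it is a floor because the value of compound 1 is the limit of > 198000 nM in this assay, at which 1 of the 3 values shown sits.

Compound 1 and compound 2 are built from the same atoms joined differently; the difference between the two cores is not broken down here. Their values in this assay are both limits and show nothing further.

Compound 4 `COc1ccc(C(=N)NC(C)C)cc1-c1cc2ccc(C(=N)NC(C)C)cc2o1` is not yet measured. From compound 2 it differs by methoxy in place of hydrogen on an aromatic carbon. This is the same kind of change as from compound 1 to compound 3, not the same: in compound 3 the methoxy is meta to a group of 6 heavy atoms, in compound 4 it is para to that group.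

Expected for compound 4 is a step of an at least 2.0-fold lower number from compound 2 to compound 4 (0.30 log units; that floor lies within the scatter), set beside an at least 2.0-fold lower number from compound 1 to compound 3 (0.30 log units; that floor lies within the scatter) and resting on that step and on the value of compound 2 being (the limit of > 200000 nM in this assay, at which 1 of the 3 values shown sits). Compound 4 is estimated at 100000 nM in this assay, within 40000 nM to 250000 nM.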

Compound 4, half-maximal inhibitory concentration: > 175000 nM
Compound 4 ended at the assay's limit; the forecaster's own chance of this, stated with the estimate: 35%; middle value at least 1.7-fold (0.24 log units) away from the limit.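

For the compounds shown here, compound 2 and compound 4 both stand only at limits in this assay, and no step between the two can be read. The compounds shown leave open whether methoxy in place of hydrogen on an aromatic carbon changes the number at all on the core of compound 2, and whether it would match the change seen on the core of compound 1.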